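Swapping the Imidazole for an Aminomethyl on the Core

The source may report more compounds than this note shows. Statements on the series, on what has been measured and on what is new or still open speak of the compounds shown alone.

Compound 1 `CCS(=O)(=O)Nc1cccc2c1CCCC2c1c[nH]cn1` is one of two compounds tested in an assay on isolated protein (Cricetulus griseus) for binding affinity to Alpha-1B adrenergic receptor (Mesocricetus auratus), read by radioligand binding (on this read-out lower numbers stand for stronger inhibition and higher numbers for weaker inhibition), and compound 1 gives 1320 nM, the lower of the two numbers. Compound 2 `COC(=O)Nc1cccc2c1CCCC2c1c[nH]cn1` gives 10000 nM in this assay; the step of a 7.6-fold higher number from compound 1 to compound 2 (0.88 log units; beyond the scatter) comes from changing the group on the ring nitrogen. Compound 3 `CCS(=O)(=O)Nc1cccc2c1CCCC2CN` keeps that sulfonyl group and instead changes the other end of the shared core: aminomethyl in place of 1H-imidazol-4-yl on a saturated ring carbon. Within the data shown here, no measured step touches this position, so the one known step, which alters a different part of the molecule, gives no direct guide to the size or direction of this change. On the compounds at hand, compound 3 is expected to bind more weakly than compound 1, with an estimated step of a 3.0-fold higher number from compound 1 to compound 3 (0.48 log units; beyond the scatter). The estimate for compound 3 in this assay is therefore 4000 nM, with a range from 1000 nM to 20000 nM.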

Compound 3, inhibition constant: < 10000 nM
Compound 3: only a limit was reported (the forecaster's own chance of this, stated with the estimate: 25%); the middle value does not contradict the limit.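

In this assay compound 3 gives < 10000 nM, which is a limit and not a number. The step from compound 1 to compound 3 therefore cannot be read. The compounds shown leave open how far, and in which direction, aminomethyl in place of 1H-imidazol-4-yl shifts the binding.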